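The compounds below may be only part of what the source reports. "The series", "measured", "known", "first", "only" and "open" are said of these compounds alone.

Measured so far in an assay on a protein complex for positive allosteric modulation of Neuronal acetylcholine receptor; alpha4/beta2 (Homo sapiens); a lower number here means a smaller maximal response, a higher number a larger maximal response:
Compound 1, `CN(Cc1cc(-c2ccccc2Cl)no1)C(=O)C1CCNCC1`, gives 41%.
Compound 2, `Clc1ccccc1-c1cc(-c2cnn(C3CCNCC3)c2)on1`, gives 38%.

Compound 2 holds the lower of these two numbers, but compound 1 sits only a few points higher, a gap within the usual scatter, so the two compounds cannot be told apart on these data. Compound 3, `Clc1sccc1-c1cc(-c2cnn(C3CCNCC3)c2)on1`, differs from compound 2 in one place: 2-chlorothiophen-3-yl in place of 2-chlorophenyl on an aromatic carbon. Within the data shown here, no measured pair of compounds shows this particular change, so there is no yardstick for it in the data. With the two measured compounds giving close maximal responses, the expectation for compound 3 is a value near that of compound 2. The expected step of a number 2 percentage points higher from compound 2 to compound 3 (within the scatter) is small, not beyond the scatter, with no clear direction. Compound 3 is therefore expected to give about 40% in this assay, in a range from 22% to 60%.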

Compound 3, largest response reached (reported as efficacy), in percent of the reference or control that the assay uses: 42%
For compound 3 the middle estimate is 2 percentage points below the measured one, and the stated range covers the measured number.
By their numbers in this assay, from the lowest: compounds 2, 1 and 3 (each within the scatter of the next).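

In this assay, putting 2-chlorothiophen-3-yl in place of 2-chlorophenyl on this aromatic carbon gives a step of a number 4 percentage points higher from compound 2 to compound 3 (within the scatter), so the two compounds cannot be told apart. Among these compounds, this is the first direct reading of this position: a six-membered aromatic ring of carbon only and a five-membered aromatic ring with a sulfur atom give maximal responses that are indistinguishable here, with the rest of the molecule kept the same. No supporting measurement is available to explain this result.

Both groups carry a chlorine and are aromatic rings, so these compounds say nothing about how the response would read with a plain phenyl, a methyl group in place of the chlorine, or a pyridine ring. On these data alone, whether any such group would move the response beyond the scatter remains open.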